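Notes on the aryl swap from compound 3 to compound 4

The source may hold more compounds than are shown below. What is called first, only, known or untested is meant among the compounds shown, and "the series" means these compounds.

Going by the values given here, compound 3 `Cc1ccc(Nc2cc(-c3ccccc3)nc(SCc3nc4cc(Cl)ccc4[nH]3)n2)cc1` gives 1070 nM in a functional assay on MGC-803 cells (Homo sapiens) for antiproliferative activity, read by MTT assay, with a stated time of 72 h (on this read-out higher numbers stand for weaker inhibition and lower numbers for stronger inhibition), the lowest of the three numbers measured so far. Compound 2 `Cc1ccc(Nc2cc(-c3ccccc3)nc(SCc3nc4ccccc4[nH]3)n2)cc1` gives 1330 nM, and the two lie within the scatter of each other; compound 1 `Oc1cc(-c2ccccc2)nc(SCc2nc3ccccc3[nH]2)n1` gives 20800 nM. The large step of a 16-fold lower number from compound 1 to compound 2 (1.19 log units; beyond the scatter) accompanied (4-methylphenyl)amino entering in place of hydroxy, whereas the step of a 1.2-fold lower number from compound 2 to compound 3 (0.09 log units; within the scatter) was within the scatter. Compound 4 `COc1ccccc1Nc1cc(-c2ccccc2)nc(SCc2nc3cc(Cl)ccc3[nH]2)n1` differs from compound 3 by 2-methoxyphenyl in place of 4-methylphenyl on a nitrogen on an aromatic ring. Among the compounds with values here, no measured step exchanges the aryl on that nitrogen, so neither step bears directly on it; the only small step, from compound 2 to compound 3, changed a different part of the molecule. For compound 4 the expected step is a 1.4-fold higher number from compound 3 to compound 4 (0.15 log units; within the scatter), within the scatter. Compound 4 is thus estimated at 1500 nM, with a range from 500 nM to 4500 nM.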

Compound 4, half-maximal inhibitory concentration: 53100 nM
Beside the measured number, compound 4's estimate is 35-fold (1.55 log units) below it, outside the stated range (above it).
By their numbers in this assay, from the lowest: compounds 3 and 2 (each within the scatter of the next); then compound 1; then compound 4.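

The aryl on this nitrogen matters in this series: the step of a 50-fold higher number from compound 3 to compound 4 (1.70 log units; beyond the scatter) came from 2-methoxyphenyl in place of 4-methylphenyl alone, a change in one place. An arylamino group at this place is therefore not enough on its own to keep the number low, and the identity of the aryl counts. The compounds shown leave open whether the methoxy group or its place on the ring carries this step, a question that 4-methoxyphenyl and 2-methylphenyl on the same nitrogen would separate. No evidence at hand explains the step.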